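This account rests on a few compounds, and the source may have more. Where it says the series, first, only, none or still open, it means among the compounds named here.

Compound 1 `COc1ncc(-c2ccc3nc(NC(=O)NCC(=O)N4CCCCC4)nn3c2)cc1NS(=O)(=O)c1ccc(F)cc1`, compound 2 `COc1ncc(-c2ccc3nc(NC(=O)N4CCCC4)nn3c2)cc1NS(=O)(=O)c1ccc(F)cc1` and compound 3 `COc1ncc(-c2ccc3nc(NC(=O)NC4CC4)nn3c2)cc1NS(=O)(=O)c1ccc(F)cc1` share one core and vary only the group on the carbonyl carbon. In a functional assay on MCF7 cells (Homo sapiens) for cytotoxicity, read by MTT assay, with a stated time of 72 h (a lower number here means a stronger inhibitor, a higher number a weaker inhibitor), compound 1 gives 570 nM, compound 2 gives 1660 nM and compound 3 gives 300 nM. Compound 2 thus holds the highest number of the three: the step of a 2.9-fold higher number from compound 1 to compound 2 (0.46 log units; beyond the scatter) and the step of a 5.5-fold lower number from compound 2 to compound 3 (0.74 log units; beyond the scatter) both lie beyond the scatter, whereas a 1.9-fold lower number from compound 1 to compound 3 (0.28 log units; within the scatter) does not. Compound 4 `CNC(=O)Nc1nc2ccc(-c3cnc(OC)c(NS(=O)(=O)c4ccc(F)cc4)c3)cn2n1` differs from compound 2 by methylamino in place of pyrrolidin-1-yl on a carbonyl carbon. Within the data shown here, the closest precedent is a 5.5-fold lower number from compound 2 to compound 3 (0.74 log units; beyond the scatter), where the same ring on the carbonyl carbon gave way to a group with one hydrogen-bond donor. A lower number is therefore expected for compound 4, roughly a 4.2-fold lower number from compound 2 to compound 4 (0.62 log units; beyond the scatter). The estimate for compound 4 in this assay is 400 nM, with a range from 150 nM to 1100 nM.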

Compound 4, half-maximal inhibitory concentration: 250 nM
The estimate for compound 4 lay 1.6-fold (0.20 log units) above the measured number; measured number inside the range.
By their numbers in this assay, from the lowest: compounds 4, 3 and 1 (each within the scatter of the next, the first and the last beyond it); then compound 2.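

Methylamino in place of pyrrolidin-1-yl on the carbonyl carbon gives a 6.6-fold lower number from compound 2 to compound 4 (0.82 log units; beyond the scatter) in this assay, so a group without a ring and with 1 hydrogen-bond donor also separates from compound 2. Methyl in place of cyclopropyl gives a 1.2-fold lower number from compound 3 to compound 4 (0.08 log units; within the scatter) and no separation on the amide-type nitrogen. Removing (piperidin-1-yl)carbonyl from the chain gives a 2.3-fold lower number from compound 1 to compound 4 (0.36 log units; beyond the scatter) and so clears the scatter, which the step from compound 1 to compound 3 did not.

As far as these compounds go, whether an ethyl group or a longer chain on that nitrogen would hold this activity remains open. No evidence in hand explains these steps.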